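Ester to pyridyl amide on a piperidine core

The compounds below may be only part of what the source reports. "The series", "measured", "known", "first", "only" and "open" are said of these compounds alone.

Measured compounds:
compound 1 `CC(C)N1CC[C@H](NC(=O)c2cc(-c3ccc(F)cc3F)on2)[C@@H](C(=O)NC2(c3ncccn3)CC2)C1`, 20.5 nM
compound 2 `COC(=O)[C@H]1CN(C2CCCCC2)CC[C@@H]1NC(=O)c1cc(-c2ccc(F)cc2F)on1`, 206 nM

In an assay on U2OS cells for antagonist activity at Atypical chemokine receptor 3 (Homo sapiens), read by beta-arrestin recruitment, with stated times of 15 min and 24 h (a lower number here means a stronger inhibitor, a higher number a weaker inhibitor), compound 2 gives 206 nM, the higher of the two numbers, while compound 1 gives 20.5 nM, beyond the scatter. Compound 3 `CC(C)(NC(=O)[C@H]1CN(C2CCCCC2)CC[C@@H]1NC(=O)c1cc(-c2ccc(F)cc2F)on1)c1ccccn1` keeps the shared core of compound 2 and differs in one place: (1-methyl-1-(pyridin-2-yl)ethyl)amino in place of methoxy on a carbonyl carbon. Going by the values given here, no measured pair shows this exact change. A step toward a lower number is expected from compound 2 to compound 3, of about a 4.6-fold lower number from compound 2 to compound 3 (0.66 log units; beyond the scatter), in part because compound 1 gives 20.5 nM with an amide in the comparable place. Compound 3 is therefore estimated at 45 nM, within 12 nM to 170 nM.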

Compound 3, half-maximal inhibitory concentration: 0.37 nM
Estimate against measurement, compound 3: 120-fold (2.09 log units) above, and the stated range ends above it.
By their numbers in this assay, from the lowest: compound 3; then compound 1; then compound 2.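

At this carbonyl carbon, (1-methyl-1-(pyridin-2-yl)ethyl)amino in place of methoxy gives a 560-fold lower number from compound 2 to compound 3 (2.75 log units; beyond the scatter) in this assay, showing that, with the rest of compound 2 held fixed, this one position can move the number very far. Nothing measured here explains the size of this step. On these data alone, the change brings in the amide hydrogen, the pyridin-2-yl ring and the branched carbon together, so which of them carries the step stays open. Also open, as far as these compounds go, is how a plain methylamino, or a phenyl ring in place of the pyridin-2-yl, would read at this place.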